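A few compounds are considered here, and "the series" means these few. Any claim that something is new, unique, unknown or untested is made for them only; others in the source may bear on it.

Within the data shown here, compound 3 `C#CCN(Cc1nc2cc(C(F)(F)F)ccc2nc1-c1ccccc1)c1ccc(F)cc1` is one of three compounds measured in an assay on isolated protein for inhibition of Dihydrofolate reductase (Homo sapiens), read by spectrophotometry; a lower number here means a stronger inhibitor, a higher number a weaker inhibitor. In this assay compound 3 gives 8000 nM. Compound 1 `COc1ccc(N(C)Cc2nc3cc(C(F)(F)F)ccc3nc2-c2ccccc2)cc1OC` gives 8000 nM in this assay, the same number at the digits shown, and compound 2 `C#CCN(Cc1nc2cc(C(F)(F)F)ccc2nc1-c1ccccc1)c1ccc(Cl)cc1` gives 4000 nM. Among the measured compounds shown here, the only step between compounds that differ in one place is a 2.0-fold higher number from compound 2 to compound 3 (0.30 log units; within the scatter), so the three numbers lie within the usual scatter of one another and no compound can be set apart from the others.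

Compound 4 `C#CCN(Cc1nc2cc(C(F)(F)F)ccc2nc1-c1ccccc1)c1ccc(OC)c(OC)c1` has not been measured in this assay. It differs from compound 3 by 3,4-dimethoxyphenyl in place of 4-fluorophenyl on an amine nitrogen. For the measured compounds named here, no measured step covers this exchange: the one step known, fluoro for chloro, is within the scatter, and compound 1, which carries the same 3,4-dimethoxyphenyl group, also differs from compound 4 on the amine nitrogen, so its value can only be taken as a loose hint. Compound 1 with 8000 nM and compound 3 with 8000 nM show the same number. The step from compound 3 to compound 4 is therefore expected to be small, a 1.1-fold lower number from compound 3 to compound 4 (0.06 log units; within the scatter), with no direction claimed beyond the scatter. Compound 4 is estimated at 7000 nM in this assay, within a range from 2500 nM to 20000 nM.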

Compound 4, inhibition constant: 3000 nM
Compound 4: the middle estimate sits 2.3-fold (0.37 log units) above what was measured; low and high end bracket the measured number.
By their numbers in this assay, from the lowest: compounds 4, 2, 1 and 3 (each within the scatter of the next, the first and the last beyond it).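

Among these compounds, on the amine nitrogen, the exchange of an aryl group now gives a first step beyond the scatter in this assay: 3,4-dimethoxyphenyl in place of 4-fluorophenyl gives a 2.7-fold lower number from compound 3 to compound 4 (0.43 log units; beyond the scatter) and is modest, while the same group in place of 4-chlorophenyl gives a 1.3-fold lower number from compound 2 to compound 4 (0.12 log units; within the scatter) and does not set compound 4 apart from compound 2. Among the compounds shown here, with 3,4-dimethoxyphenyl held fixed, a second place can also be read for the first time, since ethynyl in place of hydrogen on a saturated chain carbon bound to a nitrogen on an aromatic ring gives a 2.7-fold lower number from compound 1 to compound 4 (0.43 log units; beyond the scatter) and is likewise modest. No evidence is available that bears on what lies behind either change.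

The compounds shown leave open whether one methoxy group alone on the phenyl ring would give the same number as the pair, and whether a carboxylic acid or an amine on that ring would move it further. They also leave open whether a longer chain carrying the ethynyl group, or a plain propyl chain, would hold the number of compound 4 at the amine nitrogen.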